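The source may hold more compounds than are shown below. What is called first, only, known or untested is meant among the compounds shown, and "the series" means these compounds.

Compound 3 `Nc1nc(O)c2c(n1)n(C1OC(CO)[C@@H](O)[C@H]1O)c(=O)n2Cc1ccc(Cl)cc1` gives 15% in a functional assay on the whole organism (B cells) with Mus musculus as the target (on this read-out higher numbers stand for larger maximal responses and lower numbers for smaller maximal responses), and stands second highest of the three measured compounds, with compound 2 `Nc1nc(O)c2c(n1)n(C1OC(CO)[C@@H](O)[C@H]1O)c(=O)n2CC(O)CSc1ccccc1` at 12% nearest, a gap a number 3 percentage points higher from compound 2 to compound 3 (within the scatter), and compound 1 `Nc1nc(O)c2c(n1)n(C1OC(CO)[C@@H](O)[C@H]1O)c(=O)n2CC(O)CO` at 136% furthest, a gap a number 121 percentage points lower from compound 1 to compound 3 (beyond the scatter). The drop a number 124 percentage points lower from compound 1 to compound 2 (beyond the scatter) is of the same kind. Compound 4 `Nc1nc(O)c2c(n1)n(C1OC(CO)[C@@H](O)[C@H]1O)c(=O)n2Cc1ccc([N+](=O)[O-])cc1` carries nitro in place of chloro on an aromatic carbon. Among the compounds with values here, no measured step changes a group on the aromatic ring, so the comparison rests on the step of a number 3 percentage points higher from compound 2 to compound 3 (within the scatter), where two quite different arms on the core gave nearly the same low value; a step of little size in this assay is therefore expected for compound 4, written as a number 1 percentage points higher from compound 3 to compound 4 (within the scatter). Compound 4 is estimated at 16%, within 5% to 38%.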

Compound 4, largest response reached (reported as maximal response), in percent of the reference or control that the assay uses: 147%
Compound 4: the middle estimate sits 131 percentage points below what was measured; measured number above the stated range.
By their numbers in this assay, from the lowest: compounds 2 and 3 (each within the scatter of the next); then compound 1; then compound 4.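

Swapping chloro for nitro on the aromatic ring of the benzyl arm alone gives a large change in this assay (a number 132 percentage points higher from compound 3 to compound 4 (beyond the scatter)), so this position strongly affects the response and a benzyl arm does not by itself give a low one. The 4-nitrobenzyl arm also separates compound 4 from the arm of compound 2 (a number 135 percentage points higher from compound 2 to compound 4 (beyond the scatter)) and, more modestly, from the dihydroxypropyl-bearing arm of compound 1 (a number 11 percentage points higher from compound 1 to compound 4 (beyond the scatter)), so an aromatic arm is compatible with the highest value in the set. Nothing available explains why the two groups differ so sharply.
As far as these compounds go, whether an amine, a carboxylic acid or a nitrile in this place would side with nitro or with chloro remains open. So does whether nitro would keep this response elsewhere on the ring.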